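The source may hold more compounds than are shown below. What is called first, only, known or untested is meant among the compounds shown, and "the series" means these compounds.

Measured compounds:
Compound 1, `COc1ccc(C(C)NC(=O)/N=C(\N)NCCCc2sc(N)nc2C)cc1`: 37.2 nM
Compound 2, `Cc1nc(N)sc1CCCN/C(N)=N/C(=O)NCC(C)CCc1ccccc1`: 63.1 nM

Of the compounds shown here, two have been measured in an assay on membranes from Sf9 cells for displacement of a labelled ligand from histamine H2 receptor (Homo sapiens), read by scintillation counting, with a stated time of 60 min; a lower number here means a stronger inhibitor, a higher number a weaker inhibitor. In this assay compound 1 gives 37.2 nM, and compound 2 gives 63.1 nM; the two numbers lie within the usual scatter of each other, so neither compound can be set apart from the other on these data.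

The next compound, compound 3, `Cc1nc(N)sc1CCCN/C(N)=N/C(=O)NC(C)c1ccc(OC(F)(F)F)cc1`, is not yet measured. It is reached from compound 1 by a single change: trifluoromethyl in place of methyl on an oxygen on an aromatic ring. Within the data shown here, no measured pair in this set shows what such a change does, so there is no step here to lean on. Against that background the change is expected to leave the number where it stands, with no step beyond the scatter in either direction. For compound 3 in this assay the estimate is 40 nM, with a range from 15 nM to 110 nM. That estimate means an expected step of a 1.1-fold higher number from compound 1 to compound 3 (0.03 log units; within the scatter).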

Compound 3, inhibition constant: 126 nM
Estimate against measurement, compound 3: 3.2-fold (0.50 log units) below; measured number outside the range, above it.
By their numbers in this assay, from the lowest: compounds 1, 2 and 3 (each within the scatter of the next, the first and the last beyond it).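

Putting trifluoromethyl in place of methyl on an oxygen on an aromatic ring gives a 3.4-fold higher number from compound 1 to compound 3 (0.53 log units; beyond the scatter) in this assay. Among these compounds, this is the first sign that the group on this oxygen matters: the step lies beyond the scatter, although modest, and it runs toward a weaker inhibitor. Nothing available explains the size or direction of this step.

As this rests on a single pair, it sets no rule for other groups at this place or for the same change elsewhere in the series. From the compounds shown here alone, it remains open how an ethyl group on the same oxygen would read, or a hydroxyl group or a chlorine atom in place of the whole methoxy group.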